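Sulfonamide nitrogen substituent swap in a weakly active series

This account rests on a few compounds, and the source may have more. Where it says the series, first, only, none or still open, it means among the compounds named here.

Compound 1 `Nc1ccc(S(=O)(=O)Nc2ccnc3cc(C(F)(F)F)ccc23)cc1` gives 53700 nM in a functional assay on LoVo cells (Homo sapiens) for antiproliferative activity, read by sulforhodamine B assay, with a stated time of 48 h; a lower number here means a stronger inhibitor, a higher number a weaker inhibitor. Compound 2 `O=C(Nc1ccccc1)Nc1ccc(S(=O)(=O)Nc2ccnc3cc(C(F)(F)F)ccc23)cc1` gives 30200 nM, and a 1.8-fold lower number from compound 1 to compound 2 (0.25 log units; within the scatter). Compound 3 `Cc1cc(NS(=O)(=O)c2ccc(N/C(S)=N\c3ccnc4cc(C(F)(F)F)ccc34)cc2)on1` is reported as "not active" (no number reported), so no single number places it relative to compounds 1 and 2. Compound 4 `O=S(=O)(Nc1ccccn1)c1ccc(N/C(S)=N\c2ccnc3cc(C(F)(F)F)ccc23)cc1` differs from compound 3 only in pyridin-2-yl in place of 3-methyl-1,2-oxazol-5-yl on a sulfonamide nitrogen. For the measured compounds named here, no measured step changes the group on the sulfonamide nitrogen; the only measured step, from compound 1 to compound 2, sits elsewhere and stayed within the scatter, so it offers no direction. Given the weak numbers of compounds 1 and 2 and the inactivity of compound 3, compound 4 is expected to remain weak, estimated at 60000 nM with a range of 20000 nM to 200000 nM, with a real chance that only a limit is reported.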

Compound 4, half-maximal inhibitory concentration: 87500 nM
Compound 4: middle estimate off by 1.5-fold (0.16 log units), on the low side; the range from low to high includes it.
By their numbers in this assay, from the lowest: compounds 2, 1 and 4 (each within the scatter of the next, the first and the last beyond it).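

In this assay compound 3 is reported without a number, so the change to compound 4 gives no readable step. Going by these compounds, whether the group on the sulfonamide nitrogen affects activity stays open. Nothing available explains the result.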